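This account rests on a few compounds, and the source may have more. Where it says the series, first, only, none or still open, it means among the compounds named here.

Measured compounds in an assay for antagonist activity at proteinase-activated receptor 4 (Homo sapiens); on this read-out higher numbers stand for weaker inhibition and lower numbers for stronger inhibition:
- compound 1 `COc1ccc(-c2c(CO)n(Cc3ccc(F)cc3F)c3ccc(OC(F)(F)F)cc23)cn1`: 5110 nM; 5130 nM (2 entries)
- compound 2 `OCc1c(-c2cncnc2)c2cc(OC(F)(F)F)ccc2n1Cc1ccc(F)cc1F`: > 10000 nM
- compound 3 `CSc1ncc(-c2c(CO)n(Cc3ccc(F)cc3F)c3ccc(OC(F)(F)F)cc23)cn1`: 1350 nM; 1350 nM (2 entries)

Compound 2 stands at the edge of what this assay reports: its value is a limit, not a number, and it is the only one of the three that sits there (the limit of > 10000 nM in this assay, at which 1 of the 3 values shown sits). Compound 1 returns two concordant entries (the several entries of compound 1 in this assay, 5110 nM; 5130 nM (2 entries)), and compound 3 sits lower than compound 1 by more than the usual scatter.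

Compound 4 `COc1ncc(-c2c(CO)n(Cc3ccc(F)cc3F)c3ccc(OC(F)(F)F)cc23)cn1` is not yet measured. It differs from compound 2 by methoxy in place of hydrogen on an aromatic carbon; the same change, cut one bond further out, reads pyrimidin-5-yl to 2-methoxypyrimidin-5-yl. Within the data shown here, no step between measured compounds connects this pair, so the size cannot be taken from the numbers directly. Compound 1 carries a methoxy on its six-membered ring and gives 5110 nM; 5130 nM (2 entries), while compound 3 carries a methylthio group between two ring nitrogen atoms and gives 1350 nM; 1350 nM (2 entries); both sit clearly inside the reporting range where compound 2 does not.

For compound 4 a step beyond the scatter toward stronger inhibition is expected, an at least 3.3-fold lower number from compound 2 to compound 4 (0.52 log units; beyond the scatter). The estimate for compound 4 in this assay is 3000 nM, with a range from 1000 nM to 9000 nM.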

Compound 4, half-maximal inhibitory concentration: > 10000 nM
Compound 4 was reported as a limit; the forecaster's own chance of this, stated with the estimate: 20%; at least 3.3-fold (0.52 log units) between middle value and limit.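

Compound 2 and compound 4 are both reported only as limits, not as numbers, so no step between them can be read: the limit of > 10000 nM in this assay, at which 2 of the 4 values shown sit.

The compounds shown leave open whether methoxy in place of hydrogen on an aromatic carbon changes inhibition at all in this assay.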